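This account rests on a few compounds, and the source may have more. Where it says the series, first, only, none or still open, it means among the compounds named here.

Compound 1 `C=C(C)C(=O)NC(=O)NC1=CS(=O)(=O)O[C@@]12[C@@H](CO[Si](C)(C)C(C)(C)C)O[C@@H](n1cc(C)c(=O)n(C)c1=O)[C@@H]2O[Si](C)(C)C(C)(C)C` gives 20000 nM in a functional assay on HEL cells (Homo sapiens) for cytotoxicity, read by microscopy (a higher number here means that more compound is tolerated, a lower number that less compound is tolerated), the highest of the two numbers shown. Its nearest neighbour is compound 2 `Cc1cn([C@@H]2O[C@H](CO[Si](C)(C)C(C)(C)C)[C@@]3(OS(=O)(=O)C=C3NC(N)=O)[C@H]2O[Si](C)(C)C(C)(C)C)c(=O)n(C)c1=O`, which gives 16000 nM in this assay; the step of a 1.3-fold lower number from compound 1 to compound 2 (0.10 log units; within the scatter) lies within the scatter. Compound 3 `Cc1cn([C@@H]2O[C@H](CO[Si](C)(C)C(C)(C)C)[C@@]3(OS(=O)(=O)C=C3NCC(=O)C(N)=O)[C@H]2O[Si](C)(C)C(C)(C)C)c(=O)n(C)c1=O` reaches only a limit in this assay, >= 16000 nM. As far as these compounds go, the step that the limit leaves unreadable from compound 1 to compound 3 cannot be sized because of the limit of >= 16000 nM in this assay, at which 1 of the 3 values shown sits, and the step of a number no lower from compound 2 to compound 3 (the limit leaves the size open) is likewise open. Compound 4 `Cc1cn([C@@H]2O[C@H](CO[Si](C)(C)C(C)(C)C)[C@@]3(OS(=O)(=O)C=C3NCCC(N)=O)[C@H]2O[Si](C)(C)C(C)(C)C)c(=O)n(C)c1=O` differs from compound 1 as follows: 2-carbamoylethyl in place of ((1-methylethenyl)carbonyl)carbamoyl on an amine nitrogen. Among the compounds with values here, the one readable step on the shared core is within the scatter and the unreadable ones point no lower, so for compound 4 the expected step is a 1.3-fold lower number from compound 1 to compound 4 (0.10 log units; within the scatter), nothing beyond the scatter. Compound 4 is therefore estimated at 16000 nM in this assay, with a range from 8000 nM to 40000 nM.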

Compound 4, minimum cytotoxic concentration: >= 80000 nM
Compound 4: a limit, no number (the forecaster's own chance of this, stated with the estimate: 35%); at least 5.0-fold (0.69 log units) between middle value and limit.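

Within the data shown here, on the amine nitrogen, 2-carbamoylethyl gives the first steps beyond the scatter in this assay: an at least 4.0-fold higher number from compound 1 to compound 4 (0.60 log units; beyond the scatter), and an at least 5.0-fold higher number from compound 2 to compound 4 (0.69 log units; beyond the scatter). The value of compound 4 is a limit, not a number: the limit of >= 80000 nM in this assay, at which 1 of the 4 values shown sits. Both steps therefore give only a lower bound on the size of the change.

As far as these compounds go, the steps involving compound 3 cannot be read, so the effect of carbamoylmethyl in place of carbamoylcarbonyl stays open. Also open, from the compounds shown here alone, is how a carboxylic acid in place of the carbamoyl of 2-carbamoylethyl, or a longer chain, would read on this amine nitrogen.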